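Working notes: methoxy to hydroxymethyl

This account rests on a few compounds, and the source may have more. Where it says the series, first, only, none or still open, it means among the compounds named here.

Values in an in vivo ADME assay on the whole organism for pharmacokinetics, with Rattus norvegicus as the target; a higher number here means that the compound lasts longer, a lower number that the compound disappears faster:
- compound 1 `Cc1cc(C)c(S(N)(=O)=O)c(C)c1NC(=O)c1sccc1S(=O)(=O)Nc1onc(C)c1Cl`: 1.5 h
- compound 2 `CC(=O)OCc1c(C)cc(C)c(NC(=O)c2sccc2S(=O)(=O)Nc2onc(C)c2Cl)c1C`: 0.5 h
- compound 3 `COc1c(C)cc(C)c(NC(=O)c2sccc2S(=O)(=O)Nc2onc(C)c2Cl)c1C`: 1.8 h

Compound 3 stands level with compound 1 within the scatter, a 1.2-fold higher number from compound 1 to compound 3 (0.08 log units; within the scatter), and clear of compound 2, a 3.6-fold higher number from compound 2 to compound 3 (0.56 log units; beyond the scatter).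

Compound 4 `Cc1cc(C)c(NC(=O)c2sccc2S(=O)(=O)Nc2onc(C)c2Cl)c(C)c1CO` carries hydroxymethyl in place of methoxy on an aromatic carbon. Going by the values given here, no measured compound has hydroxymethyl at this place. The nearest evidence is the acetoxymethyl group of compound 2, with a 3.0-fold lower number from compound 1 to compound 2 (0.48 log units; beyond the scatter) against the sulfamoyl group of compound 1. The methoxy and sulfamoyl compounds show that a swap here can leave the number unmoved, so only a small fall is expected, a 1.8-fold lower number from compound 3 to compound 4 (0.26 log units; within the scatter). For compound 4 the estimate is 1 h, with an expected range of 0.4 h to 2.2 h.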

Compound 4, half-life in the Rattus norvegicus assay: 1.4 h
Compound 4: middle estimate off by 1.4-fold (0.15 log units), on the low side; measured number inside the range.
By their numbers in the Rattus norvegicus assay, from the lowest: compound 2; then compounds 4, 1 and 3 (each within the scatter of the next).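

In the Rattus norvegicus assay, hydroxymethyl sits level with both methoxy and sulfamoyl at this place, a 1.3-fold lower number from compound 3 to compound 4 (0.11 log units; within the scatter) and a 1.1-fold lower number from compound 1 to compound 4 (0.03 log units; within the scatter), so a free hydroxyl here costs nothing measurable in half-life, while the acetyl cap does: a 2.8-fold higher number from compound 2 to compound 4 (0.45 log units; beyond the scatter). In a physicochemical assay for solubility, in phosphate buffer, at pH 7.4 (a lower number here means a less soluble compound, a higher number a more soluble compound), the same swap of methoxy for hydroxymethyl gives an at least 6.5-fold higher number from compound 3 to compound 4 (0.81 log units; beyond the scatter), so the change separates the two compounds there although it does not in half-life. In the physicochemical assay compound 4 gives 65000 ug/mL. In the physicochemical assay compound 3 gives < 10000 ug/mL, so that step rests on a limit of the assay and not on a number: the limit of < 10000 ug/mL in the physicochemical assay, at which 1 of the 2 values shown sits.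

From the compounds shown here alone, the full size of that step stays open. Also open, going by these compounds, is how an aminomethyl group or a carboxylic acid at this place would read in the Rattus norvegicus assay and the physicochemical assay.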